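The source may hold more compounds than are shown below. What is called first, only, known or untested is meant among the compounds shown, and "the series" means these compounds.

Measured compounds:
- compound 1 `COc1cccc(NC(=O)C2CCN(C/C=C/c3ccccc3)CC2)c1`: 78600 nM
- compound 2 `O=C(Nc1cccc(C(F)(F)F)c1)C1CCN(C/C=C/c2ccccc2)CC1`: 11400 nM
- compound 3 `O=C(Nc1cccc2cccnc12)C1CCN(C/C=C/c2ccccc2)CC1`: 29500 nM

In a functional assay on HepG2 cells (Homo sapiens) for inhibition, read by MTT assay, with a stated time of 72 h (a lower number here means a stronger inhibitor, a higher number a weaker inhibitor), compound 1 gives 78600 nM, the highest of the three numbers. Compound 3 stands nearest to it at 29500 nM, and compound 2 furthest at 11400 nM.

Compound 4 `O=C(Nc1nccs1)C1CCN(C/C=C/c2ccccc2)CC1`, not yet measured, carries 1,3-thiazol-2-yl in place of 3-methoxyphenyl on an amide-type nitrogen.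

For the measured compounds named here, no measured step makes this exact change. The closest evidence is a 6.9-fold lower number from compound 1 to compound 2 (0.84 log units; beyond the scatter), a modest step that replaces methoxy with trifluoromethyl on an aromatic carbon. Set against compound 1, compound 3, which keeps the shared core but has a different group on the amide nitrogen, also shows a lower number, at 29500 nM. A modest move towards a lower number is therefore expected, though the evidence is thin.

The estimated change is a 2.2-fold lower number from compound 1 to compound 4 (0.35 log units; beyond the scatter).

For compound 4 the expected value is 35000 nM, with an estimated range from 12000 nM to 90000 nM.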

Compound 4, half-maximal inhibitory concentration: 22400 nM
Estimate against measurement, compound 4: 1.6-fold (0.19 log units) above; measured number inside the range.
By their numbers in this assay, from the lowest: compounds 2, 4 and 3 (each within the scatter of the next, the first and the last beyond it); then compound 1.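

In this assay, moving from a 3-methoxyphenyl to a 1,3-thiazol-2-yl on the amide-type nitrogen gives a 3.5-fold lower number from compound 1 to compound 4 (0.55 log units; beyond the scatter), which shows that this position accepts a five-membered aromatic ring with 2 hetero atoms, one of them sulfur, and not only the larger groups seen earlier. Compound 4 lies within the scatter of both compound 2 and compound 3, so three quite different groups at this nitrogen give numbers that cannot be told apart step by step, though compound 2 and compound 3 stand apart from each other. No measurement of any property of these groups is available to account for the step.

The compounds shown leave open how an amine or a carboxylic acid carried on the 1,3-thiazol-2-yl ring would read. They also leave open whether a non-aromatic group on this nitrogen, such as a simple cyclohexyl, would keep the number at this level.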